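Bromo to chloro at the benzyl group: compound 3 estimate

The source may hold more compounds than are shown below. What is called first, only, known or untested is meant among the compounds shown, and "the series" means these compounds.

Measured so far in an assay on isolated protein for inhibition of serine/threonine-protein kinase PLK1 (Homo sapiens), read by Z'-LYTE, with a stated time of 60 min; a higher number here means a weaker inhibitor, a lower number a stronger inhibitor:
compound 1 `CCOc1cc(C2CCN(C)CC2)ccc1Nc1ncc2c(n1)N(Cc1ccccc1)[C@H](CC)C(=O)N2C` gives 290 nM
compound 2 `CCOc1cc(C2CCN(C)CC2)ccc1Nc1ncc2c(n1)N(Cc1cccc(Br)c1)[C@H](CC)C(=O)N2C` gives 540 nM

Compound 2 is the starting point of this step. In this assay, among the measured compounds shown here, compound 2 gives 540 nM, and the only other number, that of compound 1, lies within the scatter of it; the two compounds cannot be told apart on these data.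

The change to compound 3 `CCOc1cc(C2CCN(C)CC2)ccc1Nc1ncc2c(n1)N(Cc1cccc(Cl)c1)[C@H](CC)C(=O)N2C` is chloro in place of bromo on an aromatic carbon. For the measured compounds named here, no pair among the measured compounds shows this exchange directly. Going by the values given here, the one step that bears on it is a 1.9-fold higher number from compound 1 to compound 2 (0.27 log units; within the scatter), which introduced the halogen at the same place and stayed within the scatter. A halogen swap at that position is a smaller change than adding the halogen, so the step from compound 2 to compound 3 in this assay is expected to be none beyond the scatter, and the estimated step is a 1.2-fold lower number from compound 2 to compound 3 (0.08 log units; within the scatter).

Compound 3 is therefore estimated at 450 nM, with a range from 200 nM to 1000 nM.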

Compound 3, half-maximal inhibitory concentration: 540 nM
For compound 3 the middle estimate is 1.2-fold (0.08 log units) below the measured one; low and high end bracket the measured number.
By their numbers in this assay, from the lowest: compounds 1, 2 and 3 (each within the scatter of the next).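

In this assay the exchange of bromo for chloro on the 3-substituted benzyl group gives no change at the digits printed from compound 2 to compound 3 (within the scatter) and so adds a second halogen reading at this place on the aromatic ring. Set against the unsubstituted benzyl of compound 1, the chloro group gives a 1.9-fold higher number from compound 1 to compound 3 (0.27 log units; within the scatter) and the bromo group gives a 1.9-fold higher number from compound 1 to compound 2 (0.27 log units; within the scatter) so that hydrogen, chloro and bromo at this one position cannot be told apart in these three compounds, where the earlier pair offered only a single halogen and could not show whether that reading held for another one. Nothing at hand accounts for this flat reading across the three compounds, and the data give no explanation of it.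

Still open, as far as these compounds go, is whether a group of a different kind at this position, such as an amine, a carboxylic acid, a methoxy group or a longer alkyl chain, would give a step beyond the scatter. The compounds shown also leave open whether chloro or bromo placed elsewhere on the same benzyl ring would read the same, since every halogen here sits at the one position.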